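Changing the ester tail on a shared crown ether core

The source may hold more compounds than are shown below. What is called first, only, known or untested is meant among the compounds shown, and "the series" means these compounds.

Measured compounds:
compound 1 `O=C(/C=C/c1ccccc1)OCC1COCCOCCOCCOCCOCCO1`: 57000 nM
compound 2 `O=C(CCCCC1CCCCC1)OCC1COCCOCCOCCOCCOCCO1`: 72000 nM

Both were tested in a functional assay on HBL-100 cells (Homo sapiens) for inhibition, read by sulforhodamine B assay, with a stated time of 48 h; on this read-out lower numbers stand for stronger inhibition of growth and higher numbers for weaker inhibition of growth. The two numbers sit close together: the step of a 1.3-fold higher number from compound 1 to compound 2 (0.10 log units; within the scatter) is within the scatter, so compound 2 cannot be told apart from compound 1 on this read-out, and it stands nowhere distinct among the two values shown.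

Compound 3 `CC(C)=CC1C(C(=O)OCC2COCCOCCOCCOCCOCCO2)C1(C)C` is not yet measured. It differs from compound 2 by a single change: 2,2-dimethyl-3-(2-methylprop-1-en-1-yl)cyclopropyl in place of 4-cyclohexylbutyl on a carbonyl carbon. Among the compounds with values here, the only step that bears on it is the one from compound 1 to compound 2, which swapped one tail for another on the same carbonyl carbon and stayed within the scatter. Exchanging the tail once more is therefore expected to give a step of about a 1.1-fold lower number from compound 2 to compound 3 (0.04 log units; within the scatter) in this assay, that is, none beyond the scatter in either direction. Compound 3 is expected to give about 65000 nM, with a range from 30000 nM to 140000 nM.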

Compound 3, concentration for 50% growth inhibition: 40000 nM
Estimate against measurement, compound 3: 1.6-fold (0.21 log units) above; low and high end bracket the measured number.
By their numbers in this assay, from the lowest: compounds 3, 1 and 2 (each within the scatter of the next).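

In this assay, the 2,2-dimethyl-3-(2-methylprop-1-en-1-yl)cyclopropyl tail brings a three-membered ring of carbon and a double bond to the carbonyl carbon, yet the result is a 1.8-fold lower number from compound 2 to compound 3 (0.26 log units; within the scatter), and measured against the 2-phenylethenyl tail it is a 1.4-fold lower number from compound 1 to compound 3 (0.15 log units; within the scatter). This position has now held three quite different carbon tails, and neither new step leaves the scatter, so compounds 1, 2 and 3 cannot be told apart on this read-out. No measurement shown here accounts for how close the three values lie.

Still open, going by these compounds, is whether a tail bearing an amine or a carboxylic acid would give a step beyond the scatter. The compounds shown also leave open how much of the growth inhibition comes from the shared core and how much from the ester tail.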